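A Methoxyphenyl Swap on a Carbonyl Carbon

This account rests on a few compounds, and the source may have more. Where it says the series, first, only, none or still open, it means among the compounds named here.

Within the data shown here, in a functional assay on MOLT-4 cells (Homo sapiens) for antiproliferative activity, read by cell counting, with a stated time of 2 days (a higher number here means a weaker inhibitor, a lower number a stronger inhibitor), compound 2 (`COc1ccc(Nc2nc(N)c(C(=O)c3ccccc3OC)s2)cc1`) gives 18 nM and holds the lower of the two numbers known so far. Compound 1 (`COc1cccc(C(=O)c2sc(Nc3ccccc3)nc2N)c1`) stands at 1300 nM in this assay, a gap beyond the scatter. These two compounds differ in more than one place, so their gap cannot be traced to any single change. Compound 3 (`COc1ccc(Nc2nc(N)c(C(=O)c3cccc(OC)c3)s2)cc1`) has the same atoms as compound 2, joined differently, with 3-methoxyphenyl in place of 2-methoxyphenyl on a carbonyl carbon. Among the measured compounds shown here, compound 1 also carries 3-methoxyphenyl on a carbonyl carbon, and its 1300 nM hints that compound 3 will lose ground, though no measured pair isolates this swap. The expected step is an 11-fold higher number from compound 2 to compound 3 (1.05 log units; beyond the scatter) in this assay, toward a weaker inhibitor and beyond the scatter. For compound 3 the estimated value is 200 nM in this assay, with 30 nM to 1300 nM as the expected range.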

Compound 3, half-maximal inhibitory concentration: 4 nM
Compound 3: middle estimate off by 50-fold (1.70 log units), on the high side; measured number below the stated range.
By their numbers in this assay, from the lowest: compound 3; then compound 2; then compound 1.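

Among these compounds, on a carbonyl carbon, 3-methoxyphenyl proves no handicap in this assay: replacing 2-methoxyphenyl gives a 4.5-fold lower number from compound 2 to compound 3 (0.65 log units; beyond the scatter), so this swap, taken alone, favours 3-methoxyphenyl in the one pair that isolates it. The weak number of compound 1 therefore cannot be laid on 3-methoxyphenyl, since that group stays in place through the much larger a 330-fold lower number from compound 1 to compound 3 (2.51 log units; beyond the scatter), where methoxy replaces hydrogen on an aromatic carbon. Nothing at hand explains either step.

The compounds shown leave open whether the swap would run the same way without that methoxy on the aromatic carbon, as only compound 1 lacks it. They also leave open how plain phenyl, 3-hydroxyphenyl or 3-ethoxyphenyl on the carbonyl carbon would compare with 3-methoxyphenyl.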